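The compounds below may be only part of what the source reports. "The series", "measured", "known", "first", "only" and "open" are said of these compounds alone.

Measured so far in a functional assay, with a stated time of 30 min; a higher number here means a weaker inhibitor, a lower number a stronger inhibitor:
- Compound 1 `O=C(/C=C/c1ccc(O)c(O)c1)CC(=O)/C=C/c1cc(O)ccc1O`: 60000 nM
- Compound 2 `O=C(/C=C/c1ccccc1O)CC(=O)/C=C/c1cc(O)ccc1O`: 48000 nM
- Compound 3 `O=C(/C=C/c1cccc(O)c1)CC(=O)/C=C/c1cc(O)ccc1O`: 88000 nM

The three compounds are not separated in this assay: compound 3, at 88000 nM, lies within the scatter of both other compounds. The next compound, compound 4 `O=C(/C=C/c1cc(O)ccc1O)CC(=O)/C=C/c1cc(O)ccc1O`, differs from compound 3 in one place: hydroxy in place of hydrogen on an aromatic carbon. In words, this is hydroxy in place of hydrogen on an aromatic carbon, turning 3-hydroxyphenyl into 2,5-dihydroxyphenyl.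

The closest measured parallel is the loss of a hydroxy from an aromatic carbon, seen in a 1.5-fold higher number from compound 1 to compound 3 (0.17 log units; within the scatter). This is a different ring position, so it is only a loose guide. The exchange of one aryl group for another, seen in a 1.8-fold higher number from compound 2 to compound 3 (0.26 log units; within the scatter) and a 1.3-fold lower number from compound 1 to compound 2 (0.10 log units; within the scatter), also bears on the question. Going by the values given here, none of these steps leaves the scatter, so the data offer no precedent for a large shift, although they cannot rule one out for this particular substitution pattern.

The expected step is small, at most a slight move toward a stronger inhibitor: a 1.8-fold lower number from compound 3 to compound 4 (0.25 log units; within the scatter). For compound 4 the estimated value is 50000 nM, with an expected range from 20000 nM to 110000 nM.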

Compound 4, half-maximal inhibitory concentration in the functional assay: 57000 nM
Compound 4: middle estimate off by 1.1-fold (0.06 log units), on the low side, within the range that was stated.
By their numbers in the functional assay, from the lowest: compounds 2, 4, 1 and 3 (each within the scatter of the next).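

In the functional assay, hydroxy in place of hydrogen on an aromatic carbon, ortho to a large group and para to a hydroxy group, gives a 1.5-fold lower number from compound 3 to compound 4 (0.19 log units; within the scatter), and hydroxy in place of hydrogen on an aromatic carbon also gives a 1.2-fold higher number from compound 2 to compound 4 (0.07 log units; within the scatter), so neither step separates the compounds. In the functional assay, rearranging the two hydroxy groups gives a 1.1-fold lower number from compound 1 to compound 4 (0.02 log units; within the scatter), so 2,5-dihydroxyphenyl and 3,4-dihydroxyphenyl are not told apart. The hydroxy change also reads alike on the two cores where it can be compared: the same change on two cores in the functional assay, a 1.5-fold higher number (0.17 log units; within the scatter) from compound 1 to compound 3 and a 1.2-fold lower number (0.07 log units; within the scatter) from compound 4 to compound 2, 1.7-fold (0.24 log units) apart, within the scatter of two such steps. In a physicochemical assay for solubility, using the shake flask method, with a stated time of 12 h (a lower number here means a less soluble compound, a higher number a more soluble compound), compound 3 gives 5800 nM and compound 4 gives 5000 nM, and the added hydroxy gives a 1.2-fold lower number from compound 3 to compound 4 (0.06 log units; within the scatter).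

From the compounds shown here alone, all four compounds carry only hydroxy groups on this ring, so it remains open whether a methoxy, an amine or a carboxylic acid on this aromatic carbon would move the number beyond the scatter. Going by these compounds, it also remains open whether any change outside this ring, such as a longer chain between the two aryl groups, would separate compounds that these hydroxy patterns leave together.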